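Removing the Cyclopropyl Amide Substituent on a Second Core

This account rests on a few compounds, and the source may have more. Where it says the series, first, only, none or still open, it means among the compounds named here.

Of the compounds shown here, three have so far been tested in a functional assay on the whole organism with Mus musculus as the target, in the rotarod test; a lower number here means that less compound is needed, a higher number that more compound is needed for the effect. Compound 1 `NC(=O)/C=C1\CCc2c(F)cc(F)cc21` carries an unsubstituted amide and gives 138 mg/kg. Compound 2 `O=C(/C=C1\CCc2c(F)cc(F)cc21)NC1CC1` bears a cyclopropyl on the amide-type nitrogen, and in this assay compound 2 gives 62 mg/kg. The step of a 2.2-fold higher number from compound 2 to compound 1 (0.35 log units; beyond the scatter) corresponds to hydrogen in place of cyclopropyl on an amide-type nitrogen. Compound 3 `O=C(/C=C1\CCc2c(F)ccc(F)c21)NC1CC1` keeps the cyclopropylamide but places it on a core in which the same atoms are joined differently; how the two cores differ is not broken down here. In this assay compound 3 gives 2 mg/kg, the lowest number of the three, and its gap to compound 2 as well as to compound 1 lies beyond the usual scatter, so compound 3 is the most potent of the measured set.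

Compound 4 `NC(=O)/C=C1\CCc2c(F)ccc(F)c21` has not yet been measured. It differs from compound 3 by hydrogen in place of cyclopropyl on an amide-type nitrogen, which is the same change, at the same place, that turns compound 2 into compound 1. If the change acts on the core of compound 3 as it did on the core of compound 2, the step of a 2.3-fold higher number from compound 3 to compound 4 (0.35 log units; beyond the scatter) is expected, resting on the single earlier step of a 2.2-fold higher number from compound 2 to compound 1 (0.35 log units; beyond the scatter). Compound 4 is accordingly estimated to give about 4.5 mg/kg in this assay. Among the compounds with values here, the expected range for compound 4 runs from 1.5 mg/kg to 15 mg/kg; it is kept wide, as only one earlier instance of this change, on a different core, is available to guide it.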

Compound 4, dose for half-maximal effect: 89 mg/kg
Estimate against measurement, compound 4: 20-fold (1.30 log units) below; measured number above the stated range.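

In this assay, replacing the cyclopropyl with hydrogen on the amide-type nitrogen of compound 3 gives a much larger step than the same change gave on the other core (a 45-fold higher number from compound 3 to compound 4 (1.65 log units; beyond the scatter)). The direction is the same on both cores, with the number rising each time, but the size of the step does not carry from one core to the other, so a step measured on one core is a poor guide to its size on the other: the same change on two cores in this assay, a 2.2-fold higher number (0.35 log units; beyond the scatter) from compound 2 to compound 1 and a 45-fold higher number (1.65 log units; beyond the scatter) from compound 3 to compound 4, 20-fold (1.30 log units) apart, beyond the scatter of two such steps. This rests on a single pair of compounds on each core, so it shows that the core can matter for this change, but it does not show why the two steps differ, nor how the change would behave on any further core.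

The compounds shown leave open whether the low number of compound 3 depends on the cyclopropyl ring itself or would be kept by another group on the same nitrogen, such as a methyl, an isopropyl, a cyclobutyl or a longer chain. They also leave open whether any such group would give steps of similar size on the two cores, or would again separate them as the cyclopropyl does.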